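Swapping a pyrazole for a pyridine: what happens to solubility

The compounds below may be only part of what the source reports. "The series", "measured", "known", "first", "only" and "open" are said of these compounds alone.

Of the compounds shown here, three have so far been measured in a physicochemical assay for solubility, read by nephelometry, measured as kinetic solubility, at pH 2; a lower number here means a less soluble compound, a higher number a more soluble compound.
Compound 1 `Cc1cc(C(=O)NNS(=O)(=O)c2ccccc2F)cc(-c2ccccn2)c1` sits at > 100 ug/mL and this is a limit of the assay rather than a number (the limit of > 100 ug/mL in this assay, at which 1 of the 3 values shown sits).
Compound 2 `Cc1cc(C(=O)NNS(=O)(=O)c2ccccc2F)cc(-n2cccn2)c1` gives 12.5 ug/mL in this assay.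
Compound 3 `Cc1cc(-n2cccn2)cc(C(=O)NNS(=O)(=O)c2ccccc2)c1F` gives 6.3 ug/mL in this assay.

Compound 1 and compound 2 share a core and differ only by pyridin-2-yl in place of 1H-pyrazol-1-yl on an aromatic carbon, which produced an at least 8.0-fold higher number from compound 2 to compound 1 (0.90 log units; beyond the scatter). Compound 3 has the same atoms as compound 2 joined differently, and the difference between the two cores is not broken down here. Compound 4 `Cc1cc(-c2ccccn2)cc(C(=O)NNS(=O)(=O)c2ccccc2)c1F` has not yet been measured. It differs from compound 3 by pyridin-2-yl in place of 1H-pyrazol-1-yl on an aromatic carbon, the same kind of change, though here the place is also para to a fluoro group. The earlier change gave an at least 8.0-fold higher number from compound 2 to compound 1 (0.90 log units; beyond the scatter). Compound 4 is expected to be reached by a step of similar size, a 7.1-fold higher number from compound 3 to compound 4 (0.85 log units; beyond the scatter). Compound 4 is therefore estimated at 45 ug/mL, likely between 15 ug/mL and 120 ug/mL.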

Compound 4, solubility: 50 ug/mL
For compound 4 the middle estimate is 1.1-fold (0.05 log units) below the measured one; the measured number falls inside the stated range.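

In this assay, putting pyridin-2-yl in place of 1H-pyrazol-1-yl gave a 7.9-fold higher number from compound 3 to compound 4 (0.90 log units; beyond the scatter), a step beyond the scatter and in the same direction as the earlier at least 8.0-fold higher number from compound 2 to compound 1 (0.90 log units; beyond the scatter), so the change carried over to the second core. The earlier step ends at a limit of the assay rather than a number, so its full size cannot be read and the two steps cannot be matched exactly: the limit of > 100 ug/mL in this assay, at which 1 of the 4 values shown sits.
Among these compounds, with only two matched pairs, this shows nothing about other cores, and it does not explain why the number rises.

The compounds shown leave open how an amine, a carboxylic acid or a longer chain at this place would read in this assay. They also leave open whether the step would hold in any other assay.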